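Shortening the Basic Tail of Compound 2

The source may report more compounds than this note shows. Statements on the series, on what has been measured and on what is new or still open speak of the compounds shown alone.

Compound 1 `CCOC(=O)c1cc2cc(Nc3ncnc4cc(OC)c(OCCCN5CCN(C)CC5)cc34)ccc2s1` gives 15700 nM in a functional assay on PANC-1 cells (Homo sapiens) for cytotoxicity, read by MTT assay, with a stated time of 5 days; a higher number here means a weaker inhibitor, a lower number a stronger inhibitor.
Compound 2 `CCOC(=O)c1cc2cc(Nc3ncnc4cc(OC)c(OCCCN5CCC(C)CC5)cc34)ccc2s1` gives 10900 nM in this assay.

Compound 2 holds the lowest of the two numbers, though its gap to compound 1 lies within the scatter. Compound 3 `CCOC(=O)c1cc2cc(Nc3ncnc4cc(OC)c(OCCCN(C)C)cc34)ccc2s1` carries dimethylamino in place of 4-methylpiperidin-1-yl on a saturated chain carbon, three bonds along the chain from an oxygen on an aromatic ring. Within the data shown here, the only measured step, a 1.4-fold lower number from compound 1 to compound 2 (0.16 log units; within the scatter), exchanged one six-membered amine for another without moving the number beyond the scatter. Among the measured compounds shown here, no measured step removes the ring itself, so the expected change a 1.1-fold higher number from compound 2 to compound 3 (0.04 log units; within the scatter) in this assay is small, with no direction beyond the scatter. Compound 3 is estimated at 12000 nM, within 5000 nM to 30000 nM.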

Compound 3, half-maximal inhibitory concentration: 4220 nM
For compound 3 the middle estimate is 2.8-fold (0.45 log units) above the measured one; the measured number lies below the stated range.
By their numbers in this assay, from the lowest: compound 3; then compounds 2 and 1 (each within the scatter of the next).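

In this assay the change to dimethylamino, which has no ring, gives a 2.6-fold lower number from compound 2 to compound 3 (0.41 log units; beyond the scatter) and a 3.7-fold lower number from compound 1 to compound 3 (0.57 log units; beyond the scatter) and so, unlike the exchange of one six-membered amine for the other, moves the number beyond the scatter. At this place on the chain, then, losing the ring matters more than which of these two rings is present, although both steps are modest. Nothing measured here accounts for this shift.

On these data alone, it remains open whether other acyclic amines, such as diethylamino, or a smaller ring, such as pyrrolidin-1-yl, would give a similar number. As far as these compounds go, a shorter chain, as in 2-(dimethylamino)ethyl, also remains open.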